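The source may report more compounds than this note shows. Statements on the series, on what has been measured and on what is new or still open speak of the compounds shown alone.

Measured in a functional assay on NCI-H460 cells (Homo sapiens) for inhibition, read by sulforhodamine B assay, with a stated time of 72 h; a lower number here means a stronger inhibitor, a higher number a weaker inhibitor:
- compound 1 `CCNC(=O)c1nnn(-c2cc(C(C)C)c(O)cc2O)c1-c1ccc(CN2CCC[C@@H](O)C2)cc1`: 52 nM
- compound 2 `CCNC(=O)c1nnn(-c2cc(C(C)C)c(O)cc2O)c1-c1ccc(CNC2CCCCC2)cc1`: 15 nM

Compound 2 stands lowest of the measured compounds at 15 nM. Compound 3 `CCNC(=O)c1nnn(-c2cc(C(C)C)c(O)cc2O)c1-c1ccc(CNCC2CCCCC2)cc1` is the next to be measured, and it differs from compound 2 as follows: cyclohexylmethyl in place of cyclohexyl on an amine nitrogen. Among the compounds with values here, the only measured step bearing on this is a 3.5-fold lower number from compound 1 to compound 2 (0.54 log units; beyond the scatter), a modest one that replaced a different amine group and does not test this change directly. No step beyond the scatter is therefore expected in this assay, so the expected change is a 1.3-fold higher number from compound 2 to compound 3 (0.12 log units; within the scatter). Compound 3 is estimated at 20 nM, with an expected range of 7 nM to 60 nM.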

Compound 3, half-maximal inhibitory concentration: 2.1 nM
The estimate for compound 3 lay 9.5-fold (0.98 log units) above the measured number; the measured number lies below the stated range.
By their numbers in this assay, from the lowest: compound 3; then compound 2; then compound 1.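

In this assay, the group on the amine nitrogen still moves the number when the carbon ring is kept: cyclohexylmethyl in place of cyclohexyl gives a 7.1-fold lower number from compound 2 to compound 3 (0.85 log units; beyond the scatter). The wider change, (cyclohexylmethyl)amino in place of 3-hydroxypiperidin-1-yl, gives a 25-fold lower number from compound 1 to compound 3 (1.39 log units; beyond the scatter), so this position has more range than the earlier pair showed. Nothing available accounts for either step.

Open, on these data alone, is whether a longer chain, such as 2-cyclohexylethyl, extends the gain or reverses it. Also open, as far as these compounds go, is whether benzyl, with an aromatic ring, can stand in for cyclohexylmethyl on this nitrogen.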